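The compounds below may be only part of what the source reports. "The series", "measured", "known", "first", "only" and "open" are said of these compounds alone.

Measured in a functional assay on A549 cells (Homo sapiens) for inhibition, read by MTT assay, with a stated time of 72 h; a lower number here means a stronger inhibitor, a higher number a weaker inhibitor:
- compound 1 `CC(C)CCN(CCCCCCC(=O)NO)c1ncc(C(=O)NCc2cccnc2)s1`: 19000 nM
- compound 2 `O=C(/C=C/c1ccc(CN(Cc2ccc(F)cc2)c2ncc(C(=O)NCCCn3ccnc3)s2)cc1)NO`: 2700 nM
- compound 3 `O=C(CCCCCCN(Cc1ccc(F)cc1)c1ncc(C(=O)NCCCn2ccnc2)s1)NO`: 9700 nM

In this assay, compound 3 sits within the scatter of compound 1, while compound 2 gives a lower number, beyond the scatter. The next compound is compound 4 `O=C(CCCCCCN(Cc1ccc(F)cc1)c1ncc(C(=O)NCc2cccnc2)s1)NO`, and its change from compound 3 is pyridin-3-yl in place of 2-(1H-imidazol-1-yl)ethyl on a saturated chain carbon bound to an amide-type nitrogen. In words, pyridin-3-yl replaces 2-(1H-imidazol-1-yl)ethyl on a saturated chain carbon bound to an amide-type nitrogen.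

Among the compounds with values here, the only measured single-place step, a 3.6-fold higher number from compound 2 to compound 3 (0.56 log units; beyond the scatter), concerns a different place and does not size this change. Compound 1 carries the same ((pyridin-3-yl)methyl)carbamoyl as compound 4 but differs from compound 3 in more than one place, so it offers only indirect guidance. Compound 1 gives 19000 nM and compound 3 gives 9700 nM, two values within the scatter of each other.

No shift beyond the scatter is therefore expected, and the estimate means a 1.1-fold higher number from compound 3 to compound 4 (0.05 log units; within the scatter). In this assay, the expected value for compound 4 is 11000 nM, with an expected range of 4500 nM to 25000 nM.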

Compound 4, half-maximal inhibitory concentration: 22000 nM
Compound 4: the middle estimate sits 2.0-fold (0.30 log units) below what was measured; the range from low to high includes it.
By their numbers in this assay, from the lowest: compound 2; then compounds 3, 1 and 4 (each within the scatter of the next, the first and the last beyond it).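

In this assay, within the data shown here, the change from 3-(1H-imidazol-1-yl)propyl to (pyridin-3-yl)methyl gives a 2.3-fold higher number from compound 3 to compound 4 (0.36 log units; beyond the scatter), the first direct reading of this position, and it shows that the position responds modestly, with the imidazole-bearing chain on the lower-number side. With ((pyridin-3-yl)methyl)carbamoyl in place, 4-fluorophenyl in place of isobutyl on a saturated chain carbon bound to a nitrogen on an aromatic ring gives a 1.2-fold higher number from compound 1 to compound 4 (0.06 log units; within the scatter), so that change leaves no readable shift in this pair. No measured evidence accounts for the step at the amide side chain.

As far as these compounds go, it remains open whether the same step holds with the 4-(2-(hydroxycarbamoyl)ethenyl)phenyl group of compound 2 in place of the 5-(hydroxycarbamoyl)pentyl chain. Also open, from the compounds shown here alone, is how a morpholine or a carboxylic acid would read on a saturated chain carbon bound to an amide-type nitrogen.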